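The source may report more compounds than this note shows. Statements on the series, on what has been measured and on what is new or still open speak of the compounds shown alone.

In a functional assay on LOX IMVI cells (Homo sapiens) for inhibition, read by sulforhodamine B assay, with a stated time of 48 h (a lower number here means a stronger inhibitor of growth, a higher number a weaker inhibitor of growth), compound 1 (`Cc1ccc(C2=NN(c3ccc(S(C)(=O)=O)cc3)C(=O)CC2)cc1`) gives 740 nM, while compound 2 (`Cc1cc(O)ccc1C1=NN(c2ccc(S(C)(=O)=O)cc2)C(=O)CC1`) gives 7250 nM. Compound 2 therefore holds the higher of the two numbers and is the weaker growth inhibitor of the pair. Among the measured compounds shown here, the only measured step is a 9.8-fold higher number from compound 1 to compound 2 (0.99 log units; beyond the scatter), a modest change that lies beyond the scatter, with 4-hydroxy-2-methylphenyl in place of 4-methylphenyl on a carbon with a double bond to nitrogen.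

Compound 3 (`CCc1ccc(C2=NN(c3ccc(S(C)(=O)=O)cc3)C(=O)CC2)cc1`) has yet to be measured in this assay. It has 4-ethylphenyl in place of the 4-hydroxy-2-methylphenyl of compound 2, at that same carbon: 4-ethylphenyl in place of 4-hydroxy-2-methylphenyl on a carbon with a double bond to nitrogen. The group that leaves is the one that accompanied the measured step, so that step is the main guide here. For the measured compounds named here, no measured compound carries 4-ethylphenyl, so its own contribution remains unknown. Most of the measured step is expected to be reversed, given the reference point of compound 1 at 740 nM. The expected change, toward a lower number, is an 8.1-fold lower number from compound 2 to compound 3 (0.91 log units; beyond the scatter). For compound 3 the estimated value is 900 nM, with an expected range from 300 nM to 2500 nM.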

Compound 3, concentration for 50% growth inhibition: 3500 nM
Estimate against measurement, compound 3: 3.9-fold (0.59 log units) below; measured number outside the range, above it.
By their numbers in this assay, from the lowest: compound 1; then compound 3; then compound 2.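

Within this assay, the step from 4-methylphenyl to 4-ethylphenyl, a 4.7-fold higher number from compound 1 to compound 3 (0.67 log units; beyond the scatter), shows that this position responds to a change in the alkyl group alone, with no hydroxy group on the ring. The step of a 2.1-fold lower number from compound 2 to compound 3 (0.32 log units; beyond the scatter) removes the hydrogen-bond donor and acceptor of 4-hydroxy-2-methylphenyl, yet it recovers only part of the earlier loss, so a higher number than that of compound 1 is not confined to the hydroxy-bearing group among these three compounds. The measurements offer no explanation for the ranking of these three groups at this carbon.

The compounds shown leave open how the hydroxy group and the added methyl of 4-hydroxy-2-methylphenyl each contribute, since the two always appear together; 4-hydroxyphenyl or 2,4-dimethylphenyl would separate them. They also leave open whether a longer chain such as propyl would raise the number further, and how a methoxy group or a chlorine atom in place of the alkyl group would compare with the methyl of compound 1.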